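A few compounds are considered here, and "the series" means these few. Any claim that something is new, unique, unknown or untested is made for them only; others in the source may bear on it.

Working notes on the series. The shared core of compound 1 `O=S(=O)(c1cccc(F)c1)c1ccc2c(c1)CCC[C@H]2CN1CCCS1(=O)=O` is kept throughout; compound 1 gives 31.6 nM in an assay on isolated protein for displacement of a labelled ligand from 5-hydroxytryptamine receptor 6 (Homo sapiens); on this read-out higher numbers stand for weaker inhibition and lower numbers for stronger inhibition. Compound 2 `O=C(NC[C@@H]1CCCc2cc(S(=O)(=O)c3cccc(F)c3)ccc21)c1ncc[nH]1` gives 15.9 nM, and the step of a 2.0-fold lower number from compound 1 to compound 2 (0.30 log units; within the scatter). Compound 3 `NC(=O)CNC[C@@H]1CCCc2cc(S(=O)(=O)c3cccc(F)c3)ccc21` gives 0.1 nM and stands lowest of the three; the steps of a 320-fold lower number from compound 1 to compound 3 (2.50 log units; beyond the scatter) and a 160-fold lower number from compound 2 to compound 3 (2.20 log units; beyond the scatter) were both large. Compound 4 `O=S(=O)(c1cccc(F)c1)c1ccc2c(c1)CCC[C@H]2CNCCO` differs from compound 3 by hydroxymethyl in place of carbamoyl on a saturated chain carbon bound to an amine nitrogen. Among the compounds with values here, no measured step covers this exact exchange; the nearest bearing is the large step of a 160-fold lower number from compound 2 to compound 3 (2.20 log units; beyond the scatter), which shows the carbamoylmethyl group weighing heavily on this read-out. Some loss is therefore expected for compound 4, with the step of a 10-fold higher number from compound 3 to compound 4 (1.00 log units; beyond the scatter) estimated, though with wide uncertainty. Compound 4 is thus estimated at 1 nM, within 0.15 nM to 8 nM.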

Compound 4, inhibition constant: 0.126 nM
Compound 4: the middle estimate sits 7.9-fold (0.90 log units) above what was measured, outside the stated range (below it).
By their numbers in this assay, from the lowest: compounds 3 and 4 (each within the scatter of the next); then compounds 2 and 1 (each within the scatter of the next).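

In this assay the exchange of carbamoyl for hydroxymethyl on a saturated chain carbon bound to an amine nitrogen gives a 1.3-fold higher number from compound 3 to compound 4 (0.10 log units; within the scatter) so the low number does not depend on the carbamoyl group alone. The 2-hydroxyethyl group keeps the large gaps to the other two groups, with a 130-fold lower number from compound 2 to compound 4 (2.10 log units; beyond the scatter) and a 250-fold lower number from compound 1 to compound 4 (2.40 log units; beyond the scatter) as the printed steps. No measurement at hand explains this.

From the compounds shown here alone, whether an ethyl group, a carboxylic acid or a 3-hydroxypropyl chain on the amine nitrogen keeps the number with those of compound 3 and compound 4 stays open.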